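Cytotoxicity limits in the hydroxyamino-pyranone amide series

The compounds below may be only part of what the source reports. "The series", "measured", "known", "first", "only" and "open" are said of these compounds alone.

Compound 1, `COC(=O)CNC(=O)c1c(NO)cc(-c2ccc(OC)cc2)oc1=O`: in an ADME assay on Huh-7 cells (Homo sapiens) for cytotoxicity, read by a luciferase reporter and WST assay, with a stated time of 3 days (a lower number here means that less compound is tolerated, a higher number that more compound is tolerated), compound 1 gives > 20000 nM, which is a limit of the assay and not a number.
Compound 2, `O=C(NCc1ccccc1)c1c(NO)cc(-c2ccccc2)oc1=O`: compound 2 gives > 20000 nM, again a limit.
Compound 3, `Cc1ccc(-c2cc(NO)c(C(=O)NCc3ccccc3)c(=O)o2)cc1`: compound 3 gives > 20000 nM, again a limit.

For the measured compounds named here, compound 3 therefore stands at the limit, together with the other two measured compounds; no compound in the set has a numerical value yet. Going by the values given here, the one measured step, a step that the two limits leave unreadable from compound 2 to compound 3, cannot be read in size because both ends are limits. Among the compounds with values here, the only evidence is the limit of > 20000 nM in this assay, at which 3 of the 3 values shown sit, which shows the whole set sitting at the same limit.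

Compound 4, `COc1ccc(-c2cc(NO)c(C(=O)NCc3ccccc3)c(=O)o2)cc1`, differs from compound 3 by methoxy in place of methyl on an aromatic carbon. Within the data shown here, no measured step bears directly on this change. Among the measured compounds shown here, compound 1 also carries a methoxyphenyl group and sits at the limit, which is the only point of comparison. Given (the limit of > 20000 nM in this assay, at which 3 of the 3 values shown sit), no step beyond the scatter is expected, and compound 4 is estimated to remain at the limit, an expected step that the limit leaves unreadable from compound 3 to compound 4. The estimate for compound 4 is 30000 nM, with a range from 20000 nM to 100000 nM.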

Compound 4, half-maximal cytotoxic concentration: > 20000 nM
Compound 4: only a limit was reported; the forecaster's own chance of this, stated with the estimate: 85%; the middle value is on the limit's open side.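

Compound 4 also gives only a limit in this assay, like compound 1, compound 2 and compound 3, and its steps from those three cannot be read. Left open is whether any numerical value separates these compounds, and whether hydrogen, methyl or methoxy on the aromatic carbon makes any difference.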